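Ester Variation on a Furyl-Bearing Core

The source may hold more compounds than are shown below. What is called first, only, known or untested is meant among the compounds shown, and "the series" means these compounds.

Compound 1 `CC1=C(C(=O)OC(C)(C)C)C(c2ccoc2)NC(=O)N1` stands as the weaker of the two compounds measured in an assay on membranes from HEK293 cells for displacement of a labelled ligand from adenosine receptor A2b (Homo sapiens), read by scintillation counting, with a stated time of 30 min (a higher number here means a weaker inhibitor, a lower number a stronger inhibitor), where compound 1 gives 4440 nM. Compound 2 `CC1=C(C(=O)OCC2CC2)C(c2ccco2)NC(=O)N1` gives 138 nM in this assay, a markedly lower number, although it differs from compound 1 in more than one place. Compound 3 `CC1=C(C(=O)OCC2CCC2)C(c2ccoc2)NC(=O)N1` carries the change (cyclobutylmethyl in place of tert-butyl on an oxygen next to a carbonyl group), tert-butoxy becoming cyclobutylmethoxy. Within the data shown here, no single-change step has been measured, so the step can only be expected: a lower number for compound 3 than for compound 1, beyond the scatter. Compound 3 is estimated at 800 nM, within 200 nM to 3000 nM, an expected step of a 5.6-fold lower number from compound 1 to compound 3 (0.74 log units; beyond the scatter).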

Compound 3, inhibition constant: 739 nM
For compound 3 the middle estimate is 1.1-fold (0.03 log units) above the measured one, and the stated range covers the measured number.
By their numbers in this assay, from the lowest: compound 2; then compound 3; then compound 1.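

The change of tert-butyl to cyclobutylmethyl on an oxygen next to a carbonyl group gives a 6.0-fold lower number from compound 1 to compound 3 (0.78 log units; beyond the scatter) in this assay and is a modest step beyond the usual scatter. Among these compounds, this is the first reading of a single change at this place, which compounds 1 and 2 could not give because they differ in more than one place. No available measurement accounts for the step.

From the compounds shown here alone, how a benzyl group or a longer straight chain on this oxygen would read remains open. So does whether the same change would give a similar step on the core of compound 2.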